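Phenyl for cyclopropyl on the side chain: expected rat exposure

The compounds below may be only part of what the source reports. "The series", "measured", "known", "first", "only" and "open" are said of these compounds alone.

Compound 1 `Cc1nc(NCC(C)C)nc(N[C@@H]2C[C@H](CO)[C@@H](O)[C@H]2O)c1-c1nc2ccccc2s1` gives 1020 ng.h/mL in an ADME assay on the whole organism (plasma) for pharmacokinetics, with Rattus norvegicus as the target, with a stated time of 6 h, at a dose of 10 mg/kg by the oral route; on this read-out lower numbers stand for lower exposure and higher numbers for higher exposure at the dose given.
Compound 2 `Cc1nc(NCC2CC2)nc(N[C@@H]2C[C@H](CO)[C@@H](O)[C@H]2O)c1-c1nc2ccccc2s1` gives 1410 ng.h/mL.
Compound 3 `Cc1nc(NCCOC(C)C)nc(N[C@@H]2C[C@H](CO)[C@@H](O)[C@H]2O)c1-c1nc2ccccc2s1` gives 426 ng.h/mL.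

Compound 2 has the highest number of the three measured compounds. The step of a 1.4-fold higher number from compound 1 to compound 2 (0.14 log units; within the scatter) stays within the scatter, so the two compounds it joins cannot be told apart, while the step of a 3.3-fold lower number from compound 2 to compound 3 (0.52 log units; beyond the scatter) is a real but modest drop. Compound 4 `Cc1nc(NCc2ccccc2)nc(N[C@@H]2C[C@H](CO)[C@@H](O)[C@H]2O)c1-c1nc2ccccc2s1` differs from compound 2 by phenyl in place of cyclopropyl on a saturated chain carbon bound to a nitrogen on an aromatic ring. Among the compounds with values here, the measured steps that touch the same position are the one from compound 1 to compound 2, which stays within the scatter, and the ones to compound 3, namely a 2.4-fold lower number from compound 1 to compound 3 (0.38 log units; beyond the scatter) and the drop from compound 2 already given. None of these steps brings in an aromatic ring, so they guide the expectation only loosely. On that basis a modest fall is expected for compound 4, namely a 2.0-fold lower number from compound 2 to compound 4 (0.30 log units; within the scatter). The estimate for compound 4 in this assay is 700 ng.h/mL, with a range from 250 ng.h/mL to 2000 ng.h/mL.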

Compound 4, area under the concentration-time curve: 1050 ng.h/mL
Estimate against measurement, compound 4: 1.5-fold (0.18 log units) below, and the stated range covers the measured number.
By their numbers in this assay, from the lowest: compound 3; then compounds 1, 4 and 2 (each within the scatter of the next).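

In this assay, a six-membered aromatic ring in place of the three-membered non-aromatic ring of cyclopropyl gives a 1.3-fold lower number from compound 2 to compound 4 (0.13 log units; within the scatter) and the exchange of isopropyl for phenyl gives a 1.0-fold higher number from compound 1 to compound 4 (0.01 log units; within the scatter) at the same place, so an aromatic ring here leaves compound 4 indistinguishable from both. Against the isopropoxymethyl group, phenyl gives a 2.5-fold higher number from compound 3 to compound 4 (0.39 log units; beyond the scatter) and this sets compound 3 apart from compound 4. Nothing shown here gives a reason for either result.

On these data alone, whether a pyridine ring, a fluorine on the phenyl ring or a longer chain ending in phenyl would keep exposure in this range remains open. So does the effect of an amine or a carboxylic acid on a saturated chain carbon bound to a nitrogen on an aromatic ring.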